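From fluoro to methyl on an aromatic carbon

The source may report more compounds than this note shows. Statements on the series, on what has been measured and on what is new or still open speak of the compounds shown alone.

Compound 1 `Nc1ncc(F)c2c1ncn2[C@@H]1C=C(CO)[C@@H](O)[C@H]1O`: 32500 nM
Compound 2 `Nc1ncc(F)c2c1ncn2[C@@H]1C=C(CCO)[C@@H](O)[C@H]1O`: > 340000 nM, a limit of the assay

Within the data shown here, in an ADME assay on MDCK cells (Canis lupus familiaris) for cytotoxicity (a lower number here means that less compound is tolerated, a higher number that more compound is tolerated), compound 1 holds the only actual number of the two results, 32500 nM. The result for compound 2 is only a limit, > 340000 nM. Compound 3 `Cc1cnc(N)c2ncn([C@@H]3C=C(CO)[C@@H](O)[C@H]3O)c12` differs from compound 1 by methyl in place of fluoro on an aromatic carbon, which is methyl in place of fluoro on an aromatic carbon. Among the measured compounds shown here, the one measured step, an at least 10-fold higher number from compound 1 to compound 2 (1.01 log units; beyond the scatter), was large, but it concerns hydroxymethyl in place of hydroxy on a saturated chain carbon. For the measured compounds named here, it therefore bears only weakly on a change at the aromatic carbon, and no measured step covers that place. No shift beyond the scatter is therefore expected, in either direction. The expected step is a 1.2-fold higher number from compound 1 to compound 3 (0.09 log units; within the scatter). For compound 3 the estimated value is 40000 nM, with an expected range of 12000 nM to 150000 nM.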

Compound 3, half-maximal cytotoxic concentration: 250000 nM
Estimate against measurement, compound 3: 6.3-fold (0.80 log units) below, outside the stated range (above it).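

Replacing fluoro with methyl on the aromatic carbon gave a 7.7-fold higher number from compound 1 to compound 3 (0.89 log units; beyond the scatter) in this assay, so this place, para to an amino group, does affect how much compound the cells tolerate. The earlier measured step lay elsewhere on the molecule; this one shows that exchanging a single heavy atom here, with no hydrogen-bond donor or acceptor entering or leaving, can move the number beyond the scatter. Compound 2 remains a limit, and the step to it has no exact size: the limit of > 340000 nM in this assay, at which 1 of the 3 values shown sits.

One pair cannot separate the effect of adding methyl from that of losing fluoro, and the compounds shown do not say how chloro, methoxy or an amine would read at this carbon. They also leave open whether the methyl change would carry over to the longer chain of compound 2.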